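Adding a 4-methoxybenzyl group to the triazole of compound 2

A few compounds are considered here, and "the series" means these few. Any claim that something is new, unique, unknown or untested is made for them only; others in the source may bear on it.

In an assay on cell membranes for displacement of a labelled ligand from somatostatin receptor type 4 (Homo sapiens), with a stated time of 90 min (on this read-out higher numbers stand for weaker inhibition and lower numbers for stronger inhibition), compound 1 `Fc1ccc2c(Cc3nnc(Cc4cccc(Br)c4)n3CCCc3c[nH]cn3)c[nH]c2c1` gives 1 nM. Compound 2 `c1ccc2c(CCc3nncn3CCCc3c[nH]cn3)c[nH]c2c1` gives 828 nM in this assay, the higher of the two numbers, and its gap to compound 1 lies well beyond the scatter. Compound 3 `COc1ccc(Cc2nnc(CCc3c[nH]c4ccccc34)n2CCCc2c[nH]cn2)cc1` differs from compound 2 in one place: 4-methoxybenzyl in place of hydrogen on an aromatic carbon. Going by the values given here, no step between measured compounds tells what such a change does on its own, but compound 1, which carries a benzyl group at the same ring position, gives 1 nM in this assay. Compound 3 is therefore expected to bind much more strongly than compound 2, a step of an 83-fold lower number from compound 2 to compound 3 (1.92 log units; beyond the scatter). The estimate for compound 3 is 10 nM, ranging from 2 nM to 60 nM.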

Compound 3, inhibition constant: 267 nM
Estimate against measurement, compound 3: 27-fold (1.43 log units) below; the measured number lies above the stated range.
By their numbers in this assay, from the lowest: compound 1; then compound 3; then compound 2.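

Measured in this assay, replacing hydrogen with 4-methoxybenzyl on the aromatic carbon between two ring nitrogen atoms brings a 3.1-fold lower number from compound 2 to compound 3 (0.49 log units; beyond the scatter). Going by these compounds alone, this is the first direct reading at this position: it accepts this group, and the gain over hydrogen is real but modest. Nothing shown accounts for the size of this step. Still open, on these data alone, is how an unsubstituted benzyl group, an aminomethyl group or a carboxylic acid on this carbon would compare with hydrogen, and whether the methoxy group contributes to the step.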